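The compounds below may be only part of what the source reports. "The series", "measured", "known", "first", "only" and "open" are said of these compounds alone.

The measured compounds:
compound 1, `CC1CCC(=O)N1CC#CCn1ccnc1`, gives 1.1 mg/kg
compound 2, `Cc1cncn1CC#CCN1C(=O)CCC1C`, gives 1.4 mg/kg
compound 3, `COC(=O)N(C)CC#CCn1ccnc1`, gives > 100 mg/kg, which is a limit of the assay and not a number

All three were tested in a functional assay on the whole organism for antagonist activity, with Mus musculus as the target; a lower number here means that less compound is needed, a higher number that more compound is needed for the effect. Compound 1 and compound 2 share one core, while compound 3 stands on a different core; the difference between the two cores is not broken down here. Compound 2 arises from compound 1 by methyl in place of hydrogen on an aromatic carbon, and that step came out as a 1.3-fold higher number from compound 1 to compound 2 (0.10 log units; within the scatter). Compound 3 is reported only as a limit of the assay, so its distance from compound 1 cannot be given as a number. What is known is the limit of > 100 mg/kg in this assay, at which 1 of the 3 values shown sits.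

Compound 4, `COC(=O)N(C)CC#CCn1cncc1C`, has not yet been measured. Among the compounds with values here, it arises from compound 3 by methyl in place of hydrogen on an aromatic carbon, which is the same change as the one from compound 1 to compound 2. On the strength of that earlier step, the change is expected to leave compound 4 about where compound 3 sits, an expected step that the limit leaves unreadable from compound 3 to compound 4. That expectation rests on the earlier step being within scatter and on compound 3 standing at a limit. Compound 4 is therefore expected most likely to be reported as a limit again. The estimate for compound 4 in this assay is 150 mg/kg, between 50 mg/kg and 500 mg/kg.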

Compound 4, dose for half-maximal effect: 5.4 mg/kg
Compound 4: the middle estimate sits 28-fold (1.44 log units) above what was measured; measured number below the stated range.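

In this assay, methyl in place of hydrogen on an aromatic carbon gave an at least 18-fold lower number from compound 3 to compound 4 (1.26 log units; beyond the scatter), so a step that was small on the core of compound 1 was large on the core of compound 3, and the change did not carry over from one core to the other with the same size: the same change on two cores in this assay, a 1.3-fold higher number (0.10 log units; within the scatter) from compound 1 to compound 2 and an at least 18-fold lower number (1.26 log units; beyond the scatter) from compound 3 to compound 4, at least 23-fold (1.37 log units) apart, beyond the scatter of two such steps. The value of compound 3 is a limit of the assay and not a number, so the size of this step is known only as a bound: the limit of > 100 mg/kg in this assay, at which 1 of the 4 values shown sits. Within the data shown here, the comparison shows that, in this series, the outcome of this change depends on the core it is made on, but it rests on only two pairs of compounds, so it gives no rule for any further core and does not show why the two steps differ.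

The compounds shown leave open whether a larger group at the same ring carbon, such as ethyl, or a halogen such as chlorine, would also separate the two cores in this way. They also leave open whether a third core, for instance one carrying an amine in place of the carbonyl-bearing part, would follow compound 2 or compound 4.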